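Chloro in Place of Fluoro: Compound 3 to Compound 4

This account rests on a few compounds, and the source may have more. Where it says the series, first, only, none or still open, it means among the compounds named here.

Measured in a functional assay on MKN-45 cells (Homo sapiens) for cytotoxicity, read by MTT assay, with a stated time of 72 h; on this read-out lower numbers stand for stronger inhibition and higher numbers for weaker inhibition:
compound 1 `CN(C)CCCNc1nc(-c2ccc(NC(=O)Nc3ccc(Cl)cc3)cc2)nc2c(Cl)c(Cl)sc12`, 1530 nM
compound 2 `CCN(CC)CCCNc1nc(-c2ccc(NC(=O)Nc3ccccc3)cc2)nc2c(Cl)c(Cl)sc12`, 1640 nM
compound 3 `CCN(CC)CCCNc1nc(-c2ccc(NC(=O)Nc3ccc(F)cc3)cc2)nc2c(Cl)c(Cl)sc12`, 1700 nM

Compound 3 gives the highest of the three numbers, but its distance to compound 2 and to compound 1 is within the scatter, so the three stand level. Compound 4 `CCN(CC)CCCNc1nc(-c2ccc(NC(=O)Nc3ccc(Cl)cc3)cc2)nc2c(Cl)c(Cl)sc12` is not yet measured; its change from compound 3 is chloro in place of fluoro on an aromatic carbon. Within the data shown here, one measured step touches the same aromatic carbon: a 1.0-fold higher number from compound 2 to compound 3 (0.02 log units; within the scatter). Compound 1 also carries a chloro there and stands level with compound 3, though it differs in a second place as well. Nothing in these numbers points to a move beyond the scatter for compound 4 in this assay; the expected step of a 1.1-fold lower number from compound 3 to compound 4 (0.03 log units; within the scatter) is small. Compound 4 is therefore estimated at 1600 nM, between 800 nM and 3200 nM.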

Compound 4, half-maximal inhibitory concentration: 720 nM
Compound 4: middle estimate off by 2.2-fold (0.35 log units), on the high side; the whole stated range lies above it.
By their numbers in this assay, from the lowest: compound 4; then compounds 1, 2 and 3 (each within the scatter of the next).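

In this assay, chloro on this aromatic carbon separates from both fluoro (a 2.4-fold lower number from compound 3 to compound 4 (0.37 log units; beyond the scatter)) and hydrogen (a 2.3-fold lower number from compound 2 to compound 4 (0.36 log units; beyond the scatter)), whereas fluoro in place of hydrogen stayed within the scatter (a 1.0-fold higher number from compound 2 to compound 3 (0.02 log units; within the scatter)). Among these compounds, with chloro held, diethylamino in place of dimethylamino also gives a step beyond the scatter (a 2.1-fold lower number from compound 1 to compound 4 (0.33 log units; beyond the scatter)), the only reading of that change. No measurement shown bears on why chloro differs from fluoro here. Open: whether bromo or trifluoromethyl on this carbon moves the number further, and whether a cyclic amine such as pyrrolidine can replace diethylamino without losing the step.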